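The source may hold more compounds than are shown below. What is called first, only, known or untested is meant among the compounds shown, and "the series" means these compounds.

Of the compounds shown here, three have so far been measured in an ADME assay on RAW264.7 cells (Mus musculus) for cytotoxicity, read by MTT assay, with a stated time of 24 h, tested at 2.5 ug/mL; a lower number here means a stronger effect, a higher number a weaker effect of the compound at the concentration tested. Compound 1, `COc1ccc(CCC(=O)c2cccc(O)c2)cc1`, gives 97.1% in this assay. Compound 2, `COc1ccc(CCC(=O)c2cccc(O)c2)c(OC)c1`, gives 88.5% in this assay. Compound 3, `COc1ccc(C(=O)/C=C/c2ccc(OC)c(OC)c2OC)c(O)c1`, gives 96.6% in this assay. The values of compound 3 and compound 1 lie within the scatter of each other, and so do those of compound 3 and compound 2.

Compound 1 and compound 2 differ in a single place: hydrogen in place of methoxy on an aromatic carbon. That change made a step of a number 8.6 percentage points higher from compound 2 to compound 1 (within the scatter).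

Compound 4, `COc1ccc(C(=O)/C=C/c2cccc(OC)c2OC)c(O)c1`, has not yet been measured. It is related to compound 3 by the same kind of change: hydrogen in place of methoxy on an aromatic carbon. The surroundings of that place are not identical, though. In compound 2 the methoxy that leaves sits ortho to a large group and meta to a methoxy group, whereas in compound 3 it sits ortho to a methoxy group, meta to a methoxy group and para to a large group. The difference between the core of compound 2 and the core of compound 3 is not broken down here.

On that basis a step of a number 0.6 percentage points lower from compound 3 to compound 4 (within the scatter) is expected, about as small as the earlier one. This expectation rests on compound 2 and compound 1, whose step a number 8.6 percentage points higher from compound 2 to compound 1 (within the scatter) lay within the scatter. For compound 4 the estimate is 96%, with a range from 86% to 103%.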

Compound 4, a percentage reported as activity, at one concentration (the size of the read-out at that concentration, not a potency): 72.9%
Beside the measured number, compound 4's estimate is 23.1 percentage points above it; the measured number lies below the stated range.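

In this assay, replacing a methoxy group with hydrogen on the core of compound 3 produced a real change, a number 23.7 percentage points lower from compound 3 to compound 4 (beyond the scatter), meaning that compound 4 has the stronger effect at the concentration tested. This shows that, in this series, the size of the step seen on one core cannot simply be carried over to another, and the same swap may give a different result elsewhere: the same change on two cores in this assay, a number 8.6 percentage points higher (within the scatter) from compound 2 to compound 1 and a number 23.7 percentage points lower (beyond the scatter) from compound 3 to compound 4, 32.3 percentage points apart, beyond the scatter of two such steps What it does not show is why, as the two cores differ in more than one place and the methoxy group that leaves has different surroundings in each, so two pairs cannot separate these differences or predict the step on a further core.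

The compounds shown carry only methoxy or hydrogen at the place that changes, so it remains open how an ethoxy group, a chlorine atom or an amine there would read in this assay. Each compound is also shown at a single concentration, which leaves open whether the gap between compound 3 and compound 4 would persist at other concentrations.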